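The source may report more compounds than this note shows. Statements on the series, on what has been measured and on what is new or still open speak of the compounds shown alone.

Values in a functional assay on MCF7 cells (Homo sapiens) for antiproliferative activity, read by sulforhodamine B assay, with a stated time of 48 h (a lower number here means a stronger inhibitor, a higher number a weaker inhibitor), so far
- compound 1 `O=C1NCCN1c1ccc(S(=O)(=O)Nc2ccc(I)cc2)cc1` gives 600 nM
- compound 2 `O=C1NCCN1c1ccc(S(=O)(=O)Nc2ccccc2)cc1` gives 470 nM
- compound 3 `CCCCOc1ccc(NS(=O)(=O)c2ccc(N3CCNC3=O)cc2)cc1` gives 870 nM

Compound 3 cannot be separated from the other two on these numbers: both a 1.5-fold higher number from compound 1 to compound 3 (0.16 log units; within the scatter) and a 1.9-fold higher number from compound 2 to compound 3 (0.27 log units; within the scatter) stay inside the scatter, as does a 1.3-fold lower number from compound 1 to compound 2 (0.11 log units; within the scatter) for the remaining pair.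

Next is compound 4 `CCCCCCOc1ccc(NS(=O)(=O)c2ccc(N3CCNC3=O)cc2)cc1` which differs from compound 3 by ethyl in place of hydrogen on a saturated chain carbon, four bonds along the chain from an oxygen on an aromatic ring and in nothing else. Going by the values given here, no measured pair changes the length of a chain, so the closest guide is the butoxy group itself. Butoxy in place of hydrogen on an aromatic carbon gave a 1.9-fold higher number from compound 2 to compound 3 (0.27 log units; within the scatter) and butoxy in place of iodo gave a 1.5-fold higher number from compound 1 to compound 3 (0.16 log units; within the scatter) in this assay with neither step clearing the scatter. A slight rise in the number is therefore expected, but no step beyond the scatter.

The expected change is a 1.1-fold higher number from compound 3 to compound 4 (0.06 log units; within the scatter) and it would sit within the scatter. Compound 4 is expected at 1000 nM with an estimated range from 400 nM to 2500 nM as its likely span.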

Compound 4, half-maximal inhibitory concentration: > 1000 nM
Compound 4 gave a limit, no number; the forecaster's own chance of this, stated with the estimate: 5%; the middle value lies on the limit itself.
By their numbers in this assay, from the lowest: compounds 2, 1 and 3 (each within the scatter of the next). At a limit, above all of these: compound 4.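

In this assay compound 4 gives > 1000 nM, which is a limit of the assay and not a number: the limit of > 1000 nM in this assay, at which 1 of the 4 values shown sits.

Even so, the only step in the series shown to clear the scatter is an at least 2.1-fold higher number from compound 2 to compound 4 (0.32 log units; beyond the scatter). The other two steps are floors that lie within the scatter, an at least 1.1-fold higher number from compound 3 to compound 4 (0.06 log units; that floor lies within the scatter) and an at least 1.6-fold higher number from compound 1 to compound 4 (0.22 log units; that floor lies within the scatter), so ethyl in place of hydrogen at this chain position cannot yet be separated from the butoxy compound, and hexyloxy cannot be separated from iodo.

From the compounds shown here alone, how far the true number lies beyond the limit remains open. Also open, going by these compounds, is how a chain ending in an amine or a carboxylic acid would read in this assay.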